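One side chain changed on compound 3

The source may report more compounds than this note shows. Statements on the series, on what has been measured and on what is new or still open speak of the compounds shown alone.

Values from a functional assay on MCF7 cells (Homo sapiens) for inhibition, read by fluorescence, with a stated time of 72 h; on this read-out higher numbers stand for weaker inhibition and lower numbers for stronger inhibition:
- Compound 1 `N=C(N)Nc1nc(N)nc2c1ncn2CCO` gives > 100000 nM (a limit, not a number)
- Compound 2 `CN(C)c1nc(N)nc2c1ncn2CCN=[N+]=[N-]` gives > 100000 nM (a limit, not a number)
- Compound 3 `CC(C)n1cnc2c(NC(=N)N)nc(NCCCO)nc21` gives 8800 nM

Only compound 3 gives an actual number in this assay, at 8800 nM. The other two values are limits. Compound 4 `CC[C@@H](CO)Nc1nc(NC(=N)N)c2ncn(C(C)C)c2n1` has not yet been measured. It differs from compound 3 in one place: 1-(hydroxymethyl)propyl in place of 3-hydroxypropyl on a nitrogen on an aromatic ring. Put simply, 1-(hydroxymethyl)propyl takes the place of 3-hydroxypropyl on a nitrogen on an aromatic ring, and the new group has a defined stereocentre. Among the compounds with values here, no measured pair shows the size of such a change, so no step beyond the usual scatter is expected in this assay. The estimated step is a 1.5-fold lower number from compound 3 to compound 4 (0.17 log units; within the scatter). For compound 4 the expected value is 6000 nM, with an estimated range from 2000 nM to 20000 nM.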

Compound 4, half-maximal inhibitory concentration: 1600 nM
Compound 4: middle estimate off by 3.8-fold (0.57 log units), on the high side; the whole stated range lies above it.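

In this assay, within the data shown here, the side chain on this nitrogen matters: 1-(hydroxymethyl)propyl in place of 3-hydroxypropyl brings a 5.5-fold lower number from compound 3 to compound 4 (0.74 log units; beyond the scatter) and gives the first step that can be read here. The two groups have the same hydrogen-bond donor and acceptor counts, so this position responds to something other than those counts.

Still open, going by these compounds, is whether the mirror-image side chain, an amine in place of the hydroxyl, or a longer chain would give a lower number. The two remaining compounds offer no further step to compare: the limit of > 100000 nM in this assay, at which 2 of the 4 values shown sit.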